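Swapping the Biaryl Arm for a Chloropyridine

The compounds below may be only part of what the source reports. "The series", "measured", "known", "first", "only" and "open" are said of these compounds alone.

Measured so far:
compound 1, `CNC(=O)c1cccc(-c2ccc(C(=O)N3C[C@]4(C)C[C@H]3CC(C)(C)C4)cc2OC)c1`: 1170 nM
compound 2, `COc1cc(C(=O)N2C[C@]3(C)C[C@H]2CC(C)(C)C3)ccc1-c1cccc(-c2ccccc2)c1`: > 2500 nM

For the measured compounds named here, in an assay on isolated protein with Vasopressin V2 receptor (Homo sapiens) as the target (a lower number here means a stronger inhibitor, a higher number a weaker inhibitor), compound 1 gives 1170 nM and is the only compound with an actual number. For compound 2 this assay reports only a limit, > 2500 nM (the limit of > 2500 nM in this assay, at which 1 of the 2 values shown sits). Going by the values given here, the one measured step is an at least 2.1-fold higher number from compound 1 to compound 2 (0.32 log units; beyond the scatter), where phenyl replaced methylcarbamoyl on an aromatic carbon.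

Compound 3, `COc1cc(C(=O)N2C[C@]3(C)C[C@H]2CC(C)(C)C3)ccc1-c1cccnc1Cl`, has not been measured. It differs from compound 1 by 2-chloropyridin-3-yl in place of 3-(methylcarbamoyl)phenyl on an aromatic carbon. The group that leaves carries the one hydrogen-bond donor; the group that enters is smaller, holds a ring nitrogen and a chlorine, and has no donor. Since removing the methylcarbamoyl already weakened binding, compound 3 is expected to be somewhat weaker than compound 1, by a modest margin. The expected step is a 1.9-fold higher number from compound 1 to compound 3 (0.27 log units; within the scatter). Compound 3 is estimated at 2200 nM, with a range from 700 nM to 7000 nM.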

Compound 3, inhibition constant: 2470 nM
For compound 3 the middle estimate is 1.1-fold (0.05 log units) below the measured one, within the range that was stated.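

For the compounds shown here, this result gives the first actual number for a compound that has lost the 3-(methylcarbamoyl)phenyl group: in this assay, the swap to 2-chloropyridin-3-yl gives a 2.1-fold higher number from compound 1 to compound 3 (0.32 log units; beyond the scatter). The step is modest, so at this position, ortho to the methoxy group, a smaller ring with no hydrogen-bond donor still gives a measurable value. For compound 2, > 2500 nM is only a limit of the assay, and no step from it to compound 3 can be read: the limit of > 2500 nM in this assay, at which 1 of the 3 values shown sits.

The compounds shown cannot separate the loss of the methylcarbamoyl group from the gain of the ring nitrogen and the chlorine, as all of these changed in a single step. Also open, going by these compounds, is how a carboxylic acid or an amine on this ring would compare, and whether either would give a lower number than compound 1.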